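The compounds below may be only part of what the source reports. "The series", "measured", "known", "first", "only" and "open" are said of these compounds alone.

Going by the values given here, compound 3 `CCO/C(O)=C1\C(COCCn2c(N)cnc2O)=NC(C)=C(C(=O)OC)C1c1ccccc1Cl` stands at the top of the numbers so far: in a functional assay (aorta) with Rattus norvegicus as the target (on this read-out higher numbers stand for weaker inhibition and lower numbers for stronger inhibition), compound 3 gives 158 nM. Compound 1 `CCO/C(O)=C1\C(COCCn2ccnc2C)=NC(C)=C(C(=O)OC)C1c1ccccc1Cl` gives 2.51 nM in this assay, and compound 2 `CCO/C(O)=C1\C(COCCN2CC(=O)N=C2N)=NC(C)=C(C(=O)OC)C1c1ccccc1Cl` gives 20 nM. The steps between them run an 8.0-fold higher number from compound 1 to compound 2 (0.90 log units; beyond the scatter), a 63-fold higher number from compound 1 to compound 3 (1.80 log units; beyond the scatter) and a 7.9-fold higher number from compound 2 to compound 3 (0.90 log units; beyond the scatter). Compound 4 `CCO/C(O)=C1\C(COCCN2CC(=O)N(C)C2=O)=NC(C)=C(C(=O)OC)C1c1ccccc1Cl` carries 3-methyl-2,4-dioxoimidazolidin-1-yl in place of 5-amino-2-hydroxy-1H-imidazol-1-yl on a saturated chain carbon, two bonds along the chain from an oxygen on a saturated carbon. Among the compounds with values here, the step that bears on it is a 7.9-fold higher number from compound 2 to compound 3 (0.90 log units; beyond the scatter), where a non-aromatic ring gave way to an aromatic one; compound 4 goes back to a non-aromatic ring, now with carbonyls and no hydrogen-bond donors, a pattern no measured compound shows, so the step seen between compound 2 and compound 3 need not simply run backwards. A modest fall in the number is nevertheless expected, not reaching the level of compound 1. For compound 4 the estimate in this assay is 30 nM, with a range from 8 nM to 120 nM. The expected step is therefore a 5.3-fold lower number from compound 3 to compound 4 (0.72 log units; beyond the scatter).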

Compound 4, half-maximal inhibitory concentration: 25.1 nM
For compound 4 the middle estimate is 1.2-fold (0.08 log units) above the measured one; measured number inside the range.
By their numbers in this assay, from the lowest: compound 1; then compounds 2 and 4 (each within the scatter of the next); then compound 3.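

The change to 3-methyl-2,4-dioxoimidazolidin-1-yl brings a 6.3-fold lower number from compound 3 to compound 4 (0.80 log units; beyond the scatter), so at this position a ring with 0 hydrogen-bond donors does not lose ground against 5-amino-2-hydroxy-1H-imidazol-1-yl. Two differently substituted five-membered non-aromatic rings cannot be told apart here, at a 1.3-fold higher number from compound 2 to compound 4 (0.10 log units; within the scatter), which lies within the scatter. The 2-methyl-1H-imidazol-1-yl group stays clearly ahead, at a 10-fold higher number from compound 1 to compound 4 (1.00 log units; beyond the scatter), yet compound 3 also carries an aromatic ring and gives the highest number, so an aromatic ring alone does not sort the series.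

Still open, going by these compounds, is how a plain tertiary amine, a carboxylic acid or a longer chain between the oxygen and the ring would compare with the 2-methyl-1H-imidazol-1-yl group. Nothing available explains why these steps run as they do.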